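The compounds below may be only part of what the source reports. "The series", "measured", "known", "first", "only" and "open" are said of these compounds alone.

Measured compounds: compound 1 `Cc1cc(O)c(C(=O)/C=C/c2ccc(F)cc2)c(-c2ccccc2)c1C(=O)/C=C/c1ccc(F)cc1` with "not active" (no number reported) in an ADME assay on HEK293 cells (Homo sapiens) for cytotoxicity, read by MTT assay, with a stated time of 24 h (on this read-out lower numbers stand for stronger inhibition and higher numbers for weaker inhibition), reported without a number; compound 2 `Cc1cc(O)c(C(=O)/C=C/c2ccc(F)cc2)c(-c2ccc(Br)cc2)c1C(=O)/C=C/c1ccc(F)cc1` with 20000 nM in this assay.

Compound 2 holds the only number shown, so it stands alone; compound 1 gives no value to set beside it. Compound 3 `Cc1cc(O)c(C(=O)/C=C/c2ccc(F)cc2)c(-c2ccc(OCc3ccccc3)cc2)c1C(=O)/C=C/c1ccc(F)cc1` differs from compound 2 by benzyloxy in place of bromo on an aromatic carbon. Going by the values given here, no measured pair shows what such a change does here, so the expected step of no change at the digits printed from compound 2 to compound 3 (within the scatter) is small and within the scatter. Compound 3 is therefore estimated at 20000 nM, within a range from 8000 nM to 50000 nM.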

Compound 3, half-maximal inhibitory concentration: 30000 nM
Beside the measured number, compound 3's estimate is 1.5-fold (0.18 log units) below it; measured number inside the range.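

In this assay, benzyloxy in place of bromo on the aromatic carbon gives a 1.5-fold higher number from compound 2 to compound 3 (0.18 log units; within the scatter). This position therefore holds both a single bromine atom and a much larger group with its own aromatic ring, and the numbers stay within the scatter of each other. Going by these compounds alone, compound 1 carries no number, so no step to it can be read. On these data alone, whether an amine or a carboxylic acid on this same aromatic carbon would also stay within the scatter remains open. Nothing available gives a reason for this result.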